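The source may report more compounds than this note shows. Statements on the series, on what has been measured and on what is new or still open speak of the compounds shown alone.

Measured in an ADME assay on CEM-SS cells (Homo sapiens) for cytotoxicity, read by XTT assay; on this read-out higher numbers stand for lower toxicity in this test and lower numbers for higher toxicity in this test:
Compound 1 `CN(O)C(=O)c1cc2c(CN3CCC(O)C3)cn(Cc3ccc(F)cc3)c2cn1`: > 100000 nM (a limit of the assay)
Compound 2 `CN(O)C(=O)c1cc2c(COC3CCOCC3)cn(Cc3ccc(F)cc3)c2cn1`: > 100000 nM (a limit of the assay)
Compound 3 `COCc1cn(Cc2ccc(F)cc2)c2cnc(C(=O)N(C)O)cc12`: 266000 nM

Compound 3 is the only one of the three with an actual number, 266000 nM. Compound 1 and compound 2 give only (the limit of > 100000 nM in this assay, at which 2 of the 3 values shown sit).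

The next compound is compound 4 `CN(O)C(=O)c1cc2c(CCCO)cn(Cc3ccc(F)cc3)c2cn1`, which departs from compound 3 in one place: 2-hydroxyethyl in place of methoxy on a saturated chain carbon bound to an aromatic carbon. In words, 2-hydroxyethyl stands in place of methoxy on a saturated chain carbon bound to an aromatic carbon. Cut one bond further out, the same difference reads methoxymethyl to 3-hydroxypropyl.

Three measured steps involve changes at this same place: a step that the limit leaves unreadable from compound 1 to compound 3, a step that the limit leaves unreadable from compound 2 to compound 3 and a step that the two limits leave unreadable from compound 1 to compound 2. None of them has a readable size, so they offer no measured effect to carry over. Within the data shown here, the expectation therefore rests on compound 3 at 266000 nM, the only number available in this assay.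

The expected result is a 1.3-fold lower number from compound 3 to compound 4 (0.12 log units; within the scatter), with no step beyond the scatter and no direction favoured. A report of a limit alone would be quite possible. For compound 4 the estimate is 200000 nM, with an expected range from 90000 nM to 400000 nM.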

Compound 4, half-maximal cytotoxic concentration: > 10000 nM
Compound 4: only a limit was reported; the forecaster's own chance of this, stated with the estimate: 50%; the middle value lies beyond the limit too.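

Compound 4 is reported only as a limit, and none of its steps from compound 1, compound 2 or compound 3 can be read. The compounds shown leave open whether 3-hydroxypropyl in place of methoxymethyl changes the read-out at all, and by how much, with compound 3 alone carrying an actual number.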